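Methoxy on the indole ring: a nitro-bearing analog awaits testing

A few compounds are considered here, and "the series" means these few. Any claim that something is new, unique, unknown or untested is made for them only; others in the source may bear on it.

Compound 1 `COc1ccc2c(/C=C(\C)C(=O)c3cc(OC)c(OC)c([Se]C)c3)c[nH]c2c1` and compound 2 `COc1cc(C(=O)/C(C)=C/c2c[nH]c3ccccc23)cc([Se]C)c1OC` share a core, and in a functional assay on A549 cells (Homo sapiens) for antiproliferative activity, read by MTT assay, with a stated time of 48 h (on this read-out lower numbers stand for stronger inhibition and higher numbers for weaker inhibition), compound 1 gives 8 nM while compound 2 gives 12 nM. Among the measured compounds shown here, the one change between them, (methoxy in place of hydrogen on an aromatic carbon), produced a 1.5-fold lower number from compound 2 to compound 1 (0.18 log units; within the scatter). Compound 3 `COc1cc(C(=O)/C=C/c2cn(C)c3ccccc23)cc([N+](=O)[O-])c1OC` is built on a different core; how its core differs from that of compound 2 is not broken down here. In this assay compound 3 gives 1060 nM, the highest number of the three measured. Compound 4 `COc1ccc2c(/C=C/C(=O)c3cc(OC)c(OC)c([N+](=O)[O-])c3)cn(C)c2c1` has not yet been measured. It differs from compound 3 by methoxy in place of hydrogen on an aromatic carbon, the same change that turned compound 2 into compound 1. Resting on that earlier step, the expected step is a 1.3-fold lower number from compound 3 to compound 4 (0.12 log units; within the scatter). Compound 4 is therefore estimated at 800 nM, with a likely range from 300 nM to 2500 nM.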

Compound 4, half-maximal inhibitory concentration: 1020 nM
Estimate against measurement, compound 4: 1.3-fold (0.11 log units) below; measured number inside the range.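

In this assay, methoxy in place of hydrogen on an aromatic carbon gives a 1.0-fold lower number from compound 3 to compound 4 (0.02 log units; within the scatter), so on this core, as on the earlier one, the two compounds cannot be told apart. The two steps agree with each other: the same change on two cores in this assay, a 1.5-fold lower number (0.18 log units; within the scatter) from compound 2 to compound 1 and a 1.0-fold lower number (0.02 log units; within the scatter) from compound 3 to compound 4, 1.4-fold (0.16 log units) apart, within the scatter of two such steps. This shows that the change carried from one core to the other without a step beyond the scatter on either, but it does not show that methoxy does anything to the number in this assay, and two cores cannot speak for the rest of the series.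

The compounds shown leave open whether an ethoxy, a hydroxy or an amine on that aromatic carbon would give a step beyond the scatter on either core.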